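Tert-butyl for nitro on the benzyl ether of compound 1

The source may report more compounds than this note shows. Statements on the series, on what has been measured and on what is new or still open speak of the compounds shown alone.

Compound 1 `CCC1(Cc2ccccc2)OS(=O)(=O)C=C1OCc1ccc([N+](=O)[O-])cc1` — in an ADME assay on HEL cells (Homo sapiens) for cytotoxicity, with a stated time of 3 days (a higher number here means that more compound is tolerated, a lower number that less compound is tolerated), compound 1 gives >= 80000 nM
Compound 2 `C=CCOC1=CS(=O)(=O)OC1(CC)Cc1ccccc1` — in this assay compound 2 gives 80000 nM

Compound 1 stands at >= 80000 nM in this assay, and this is a limit of the assay rather than a number. Compound 2, in which vinyl replaces 4-nitrophenyl on a saturated chain carbon bound to an oxygen on an unsaturated carbon, gives 80000 nM. The step of a number no higher from compound 1 to compound 2 (the limit leaves the size open) is all that has been measured so far, and its size cannot be read because of the limit of >= 80000 nM in this assay, at which 1 of the 2 values shown sits.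

Compound 3 `CCC1(Cc2ccccc2)OS(=O)(=O)C=C1OCc1ccc(C(C)(C)C)cc1` keeps the benzyl ether of compound 1 and changes only the group on its aromatic ring: tert-butyl in place of nitro on an aromatic carbon. Going by the values given here, no measured step touches that position; the one step known, from compound 1 to compound 2, swaps the whole aryl group and leaves the reading at the limit. With nothing to suggest a change beyond the scatter, compound 3 is expected to give 80000 nM, with a range from 40000 nM to 160000 nM. The expected step is a number no higher from compound 1 to compound 3 (the limit leaves the size open), most likely again reported only as a limit.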

Compound 3, minimum cytotoxic concentration: >= 400000 nM
Compound 3 gave a limit, no number (the forecaster's own chance of this, stated with the estimate: 70%); middle value at least 5.0-fold (0.69 log units) away from the limit.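

Compound 1 and compound 3 are both reported in this assay only as limits of the assay and not as numbers, so no step can be read between them. The compounds shown leave open whether tert-butyl in place of nitro on an aromatic carbon changes the minimum cytotoxic concentration at all, and by how much.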